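Dimethoxyphenyl for thiophenyl on the carbonyl carbon: compound 4

The compounds below may be only part of what the source reports. "The series", "measured", "known", "first", "only" and "open" are said of these compounds alone.

Of the compounds shown here, three have been measured in a functional assay on HCT-116 cells (Homo sapiens) for inhibition, read by sulforhodamine B assay, with a stated time of 72 h; on this read-out higher numbers stand for weaker inhibition and lower numbers for stronger inhibition. Compound 1 `O=C(/C=C/c1cn(-c2ccccc2)nc1-c1cccnc1)c1ccsc1` gives 1300 nM, compound 2 `COc1ccc(OC)c(C(=O)/C=C/c2cn(-c3ccccc3)nc2-c2cccnc2)c1` gives 1000 nM, and compound 3 `O=C(/C=C/c1cn(-c2ccccc2)nc1-c1ccncc1)c1ccsc1` gives 1100 nM. Compound 3 stands second highest of the three numbers, yet its nearest neighbour compound 2 and its furthest neighbour compound 1 both lie within the scatter of it, so no order among the three can be read from this assay.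

The unmeasured compound 4 `COc1ccc(C(=O)/C=C/c2cn(-c3ccccc3)nc2-c2ccncc2)cc1OC` differs from compound 3 in one place: 3,4-dimethoxyphenyl in place of thiophen-3-yl on a carbonyl carbon. Among the compounds with values here, the step that bears on this change is the one from compound 1 to compound 2, where a dimethoxyphenyl group also replaced thiophen-3-yl on the carbonyl carbon: a 1.3-fold lower number from compound 1 to compound 2 (0.11 log units; within the scatter). The two methoxy groups sit differently there, but the data hold no other comparison. The other measured step, a 1.2-fold lower number from compound 1 to compound 3 (0.07 log units; within the scatter), concerns the pyridyl group and is likewise within the scatter.

On this basis a step no larger than the scatter is expected from compound 3 to compound 4, a 1.2-fold lower number from compound 3 to compound 4 (0.09 log units; within the scatter), with no direction that can be trusted. Compound 4 is therefore estimated at 900 nM in this assay, within the range 450 nM to 1800 nM.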

Compound 4, half-maximal inhibitory concentration: 1200 nM
Compound 4: middle estimate off by 1.3-fold (0.12 log units), on the low side, within the range that was stated.
By their numbers in this assay, from the lowest: compounds 2, 3, 4 and 1 (each within the scatter of the next).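

In this assay, the new step, a 1.1-fold higher number from compound 3 to compound 4 (0.04 log units; within the scatter), shows that 3,4-dimethoxyphenyl on a carbonyl carbon, with 10 heavy atoms and 2 hydrogen-bond acceptors, leaves the number within the scatter of the value with thiophen-3-yl, which has 5 heavy atoms and 1 hydrogen-bond acceptor. The earlier swap at this place, a 1.3-fold lower number from compound 1 to compound 2 (0.11 log units; within the scatter), involved 2,5-dimethoxyphenyl on the pyridin-3-yl compound, so the series now holds a second arrangement of the two methoxy groups, on the pyridin-4-yl compound, and neither replacement of thiophen-3-yl moves the number beyond the scatter. No measurement bearing on this result accompanies these compounds, so nothing can be said of what lies behind it.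

Within the data shown here, no step exceeds the scatter. The compounds shown do not reveal which changes at this place, if any, would shift the number. Still open, from the compounds shown here alone, are a phenyl ring with a single methoxy group on the carbonyl carbon and non-aromatic replacements there, such as a longer chain ending in an amine or a carboxylic acid.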